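Swapping a cyclohexyl for a dimethylphenyl on the amide chain

A few compounds are considered here, and "the series" means these few. Any claim that something is new, unique, unknown or untested is made for them only; others in the source may bear on it.

Measured so far in a functional assay on Jurkat cells (Homo sapiens); a lower number here means a stronger inhibitor, a higher number a weaker inhibitor:
compound 1, `C[C@H](NC(=O)C(=O)NCc1ccc(Cl)cc1)C(=O)N[C@@H](CC(=O)O)C(=O)COc1c(F)c(F)cc(F)c1F`: 8.4 nM
compound 2, `C[C@H](NC(=O)C(=O)NCC1CCCCC1)C(=O)N[C@@H](CC(=O)O)C(=O)COc1c(F)c(F)cc(F)c1F`: 19 nM
compound 3, `C[C@H](NC(=O)C(=O)NCC1(c2ccccc2)CC1)C(=O)N[C@@H](CC(=O)O)C(=O)COc1c(F)c(F)cc(F)c1F`: 27 nM

Compound 2 holds the second highest of the three numbers in this assay. Its nearest neighbour is compound 3, reached by a 1.4-fold higher number from compound 2 to compound 3 (0.15 log units; within the scatter), a gap within the scatter. Its furthest is compound 1, from which it is separated by a 2.3-fold higher number from compound 1 to compound 2 (0.35 log units; beyond the scatter).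

Compound 4, `Cc1ccc(C)c(CNC(=O)C(=O)N[C@@H](C)C(=O)N[C@@H](CC(=O)O)C(=O)COc2c(F)c(F)cc(F)c2F)c1`, differs from compound 2 in one place: 2,5-dimethylphenyl in place of cyclohexyl on a saturated chain carbon bound to an amide-type nitrogen

For the measured compounds named here, the step that bears most on this change is the one from compound 1 to compound 2, where a six-membered aromatic ring gave way to cyclohexyl and the number rose modestly, a 2.3-fold higher number from compound 1 to compound 2 (0.35 log units; beyond the scatter). The change from compound 2 to compound 4 runs the other way, back to a six-membered aromatic ring, though one bearing two methyl groups rather than a chlorine. The steps from compound 1 to compound 3, a 3.2-fold higher number from compound 1 to compound 3 (0.51 log units; beyond the scatter), and from compound 2 to compound 3, a 1.4-fold higher number from compound 2 to compound 3 (0.15 log units; within the scatter), show that the other variations at this position stayed modest. A modest step downward is therefore expected, a 1.7-fold lower number from compound 2 to compound 4 (0.24 log units; within the scatter), with the possibility that it falls within the scatter. Compound 4 is estimated at 11 nM, within a range of 4.5 nM to 27 nM.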

Compound 4, half-maximal inhibitory concentration: 11 nM
For compound 4 middle estimate and measured number coincide at the digits printed; measured number inside the range.
By their numbers in this assay, from the lowest: compounds 1, 4, 2 and 3 (each within the scatter of the next, the first and the last beyond it).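

In this assay, the 2,5-dimethylphenyl of compound 4 cannot be told apart from either the cyclohexyl or the 4-chlorophenyl at this position, since both steps stand within the scatter (a 1.7-fold lower number from compound 2 to compound 4 (0.24 log units; within the scatter); a 1.3-fold higher number from compound 1 to compound 4 (0.12 log units; within the scatter)). For the compounds shown here, only one new step clears the scatter (a 2.5-fold lower number from compound 3 to compound 4 (0.39 log units; beyond the scatter)), so 2,5-dimethylphenyl stands apart from 1-phenylcyclopropyl, a separation that cyclohexyl did not reach. No measurement offered here accounts for these differences.

On these data alone, whether a single methyl group on the ring would serve as well as two, and whether a methoxy group, an amine or a carboxylic acid on the ring would hold the number, remains open. So does the effect of a longer chain carrying the ring.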